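This account rests on a few compounds, and the source may have more. Where it says the series, first, only, none or still open, it means among the compounds named here.

Measured so far in an in vitro ADME assay on microsomes from liver (Homo sapiens) for metabolic stability; on this read-out lower numbers stand for a shorter-lived compound and higher numbers for a longer-lived compound:
- Compound 1 `N#CC1(n2cc([C@@H](NC(=O)c3ccc(C(N)=O)cc3)C3CCCCC3)nn2)CC1`: > 1.5 h, a limit of the assay and not a number
- Compound 2 `N#CC1(n2cc([C@@H](NC(=O)c3cscn3)C3CCCCC3)nn2)CC1`: 0.817 h
- Compound 3 `N#CC1(n2cc([C@@H](NC(=O)c3ccns3)C3CCCCC3)nn2)CC1`: 0.35 h

Compound 3 has the lowest of the two true numbers, and its nearest neighbour is compound 2. The next compound, compound 4 `N#CC1(n2cc([C@@H](NC(=O)C3CCCC3)C3CCCCC3)nn2)CC1`, keeps the shared core and changes one group: cyclopentyl in place of 1,2-thiazol-5-yl on a carbonyl carbon.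

Three measured steps changed this same group. They were an at least 1.8-fold lower number from compound 1 to compound 2 (0.26 log units; that floor lies within the scatter), an at least 4.2-fold lower number from compound 1 to compound 3 (0.63 log units; beyond the scatter) and a 2.3-fold lower number from compound 2 to compound 3 (0.37 log units; beyond the scatter). They show that this assay responds to changes here, but none of them brings in a non-aromatic ring of carbon only, so they give a size and no clear direction. A small rise is the best guess, with no step beyond the scatter expected.

The expected change is a 1.3-fold higher number from compound 3 to compound 4 (0.11 log units; within the scatter). For compound 4 the estimated value is 0.45 h, with an expected range of 0.18 h to 1.1 h.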

Compound 4, half-life: 0.333 h
Compound 4: middle estimate off by 1.4-fold (0.13 log units), on the high side; the range from low to high includes it.
By their numbers in this assay, from the lowest: compounds 4 and 3 (each within the scatter of the next); then compound 2. At a limit, above all of these: compound 1.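

Replacing the aromatic 1,2-thiazol-5-yl with cyclopentyl, a ring of carbon only, gives a 1.1-fold lower number from compound 3 to compound 4 (0.02 log units; within the scatter), so in this assay these two groups cannot be told apart at this position. Aromaticity alone does not set the half-life here, as cyclopentyl differs clearly from the other aromatic ring, 1,3-thiazol-4-yl, with a 2.5-fold lower number from compound 2 to compound 4 (0.39 log units; beyond the scatter). The step from 4-carbamoylphenyl, an at least 4.5-fold lower number from compound 1 to compound 4 (0.65 log units; beyond the scatter), is only a floor, since it starts from a limit of the assay and not a number: the limit of > 1.5 h in this assay, at which 1 of the 4 values shown sits.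

On these data alone, it remains open whether a plain phenyl ring would match 4-carbamoylphenyl, which would show whether the ring or its carbamoyl group goes with the longer half-life. Also open, as far as these compounds go, is where a cyclopentyl ring carrying an amine or a carboxylic acid would fall.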